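Nitro to (Dimethylcarbamoyl)amino: What to Expect

The source may hold more compounds than are shown below. What is called first, only, known or untested is meant among the compounds shown, and "the series" means these compounds.

Compound 1 `CCOc1ccc(-c2ccccc2)cc1`: 35%
Compound 2 `CCOc1ccc(-c2cccc([N+](=O)[O-])c2)cc1`: 35%

Of the compounds shown here, two have been measured in an assay on COS-7 cells for inhibition of patatin-like phospholipase domain-containing protein 2 (Mus musculus), tested at 200 uM; on this read-out lower numbers stand for less inhibition and higher numbers for more inhibition at the one concentration tested (going by the name of the read-out). Compound 1, the parent with an unsubstituted outer ring, gives 35%. Compound 2 carries a nitro group on that ring and gives 35%. The step of no change at the digits printed from compound 1 to compound 2 (within the scatter) therefore shows that adding a nitro group in place of hydrogen left the read-out where it was; compound 2 stands level with compound 1 within the scatter, and the inhibition in this assay is level for the two on these numbers.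

Compound 3 `CCOc1ccc(-c2cccc(NC(=O)N(C)C)c2)cc1` is the next candidate. It differs from compound 2 by (dimethylcarbamoyl)amino in place of nitro on an aromatic carbon.

For the measured compounds named here, only one measured step exists, and it concerns the same position, though with a different exchange: hydrogen to nitro, which was flat. Going by the values given here, no compound with a (dimethylcarbamoyl)amino group has been measured, so there is no direct precedent for this entering group. Among the compounds with values here, with the single relevant step showing no movement, the expected step of no change at the digits printed from compound 2 to compound 3 (within the scatter) is no change beyond the scatter. Compound 3 is therefore estimated at 35%, with a range from 15% to 55%.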

Compound 3, a percentage reported as inhibition, at one concentration (the size of the read-out at that concentration, not a potency): 68%
Estimate against measurement, compound 3: 33 percentage points below; measured number outside the range, above it.
By their numbers in this assay, from the lowest: compounds 1 and 2 (each within the scatter of the next); then compound 3.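

In this assay, putting (dimethylcarbamoyl)amino on this aromatic carbon gives a number 33 percentage points higher from compound 2 to compound 3 (beyond the scatter), and measured against the unsubstituted parent it gives a number 33 percentage points higher from compound 1 to compound 3 (beyond the scatter). The position therefore does not respond the same way to every group: the flat exchange of hydrogen for nitro said something about nitro, not about the position as a whole. The computed comparison shows that the entering group has more heavy atoms than nitro and a hydrogen-bond donor that nitro lacks, but no available measurement connects either difference with the higher inhibition.

The compounds shown leave open which part of the new group matters, since a plain amino group, an acetylamino group or a (methylcarbamoyl)amino group on the same carbon would separate the contributions of its pieces. They also leave open whether (dimethylcarbamoyl)amino would do the same on another carbon of that ring, and how the inhibition at this single concentration would translate into a potency.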